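This account rests on a few compounds, and the source may have more. Where it says the series, first, only, none or still open, it means among the compounds named here.

In a functional assay on NCI-H23 cells (Homo sapiens) for cytotoxicity, read by sulforhodamine B assay, with a stated time of 48 h (on this read-out lower numbers stand for higher toxicity in this test and higher numbers for lower toxicity in this test), three compounds built on a shared core have been measured. Compound 1 `Nc1nc(Cl)c2ncn(Cc3ccccc3CCl)c2n1` gives 78900 nM, compound 2 `ClCc1ccc(Cn2cnc3ncnc(Cl)c32)cc1` gives 58900 nM, and compound 3 `ClCc1cccc(Cn2cnc3ncnc(Cl)c32)c1` gives 5880 nM. Compound 2 thus holds the second highest of the three numbers: its value sits within the scatter of compound 1, while compound 3 lies well beyond the scatter from it.

Compound 4 `ClCc1ccc(Cn2cnc3nc(Cl)nc(Cl)c32)cc1` has not yet been measured in this assay. It differs from compound 2 by chloro in place of hydrogen on an aromatic carbon. For the measured compounds named here, no measured pair shows this change, so its effect is unknown. For compound 4 the expected step of a 1.3-fold lower number from compound 2 to compound 4 (0.12 log units; within the scatter) is small and likely stays within the scatter. Compound 4 is therefore estimated at 45000 nM, within a range from 15000 nM to 130000 nM.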

Compound 4, concentration lethal to 50% of the cells: 8910 nM
The estimate for compound 4 lay 5.1-fold (0.70 log units) above the measured number, and the stated range ends above it.
By their numbers in this assay, from the lowest: compounds 3 and 4 (each within the scatter of the next); then compounds 2 and 1 (each within the scatter of the next).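

In this assay, for the compounds shown here, chloro in place of hydrogen on the aromatic carbon between two ring nitrogen atoms gives a 6.6-fold lower number from compound 2 to compound 4 (0.82 log units; beyond the scatter), the first single-place change that can be read. Going by these compounds alone, it shows that the number is sensitive to substitution at this position, though only this one pair supports that. No available evidence explains the size of this step.

Going by these compounds, whether a fluoro or a methoxy group on this carbon would shift the number in the same way remains open. So does whether chloro there would have a similar effect in compound 3.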